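Benzylamino in place of phenethyl: cytotoxicity at the limit

A few compounds are considered here, and "the series" means these few. Any claim that something is new, unique, unknown or untested is made for them only; others in the source may bear on it.

Compound 1 `Cn1c(Cc2ccccc2C(F)(F)F)nc(C(=O)Nc2ccccc2)c(O)c1=O`: in an ADME assay on HepG2 cells (Homo sapiens) for cytotoxicity, in the presence of a further agent that is not named here (a lower number here means a stronger inhibitor, a higher number a weaker inhibitor), compound 1 gives > 100000 nM, which is a limit of the assay and not a number.
Compound 2 `COc1nc(C(C)c2ccccc2C(F)(F)F)nc(C(=O)NCc2ccccc2)c1O`: in this assay compound 2 gives > 100000 nM, again a limit.
Compound 3 `Cn1c(Cc2ccccc2C(F)(F)F)nc(C(=O)CCc2ccccc2)c(O)c1=O`: in this assay compound 3 gives > 100000 nM, also a limit.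

Compound 3 therefore stands at the limit of this assay, the same place at which every measured value of this set sits (the limit of > 100000 nM in this assay, at which 3 of the 3 values shown sit). Within the data shown here, the only measured step that touches it, a step that the two limits leave unreadable from compound 1 to compound 3, runs between two limits, so its size cannot be read, and it says nothing about the direction in which the carbonyl substituent moves the read-out.

Compound 4 `Cn1c(Cc2ccccc2C(F)(F)F)nc(C(=O)NCc2ccccc2)c(O)c1=O` differs from compound 3 by benzylamino in place of phenethyl on a carbonyl carbon. Among the measured compounds shown here, no measured step bears directly on this change. Compound 2 carries the same benzylamino group on its carbonyl carbon, on a different core, and also returns a limit, so nothing in the data points to a step beyond the scatter in this assay in either direction.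

Compound 4 is accordingly expected to sit at the limit as well, with an estimated value of 100000 nM and a range from 50000 nM to 300000 nM. The step this estimate implies, a number no higher from compound 3 to compound 4 (the limit leaves the size open), is expected to be none beyond the scatter.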

Compound 4, half-maximal inhibitory concentration: > 100000 nM
Compound 4: a limit, no number (the forecaster's own chance of this, stated with the estimate: 85%); the middle value lies on the limit itself.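

In this assay compound 4 gives > 100000 nM as a limit of the assay and not a number. No new step can be read from compound 1 or compound 3 to compound 4, as each pair runs between two limits: the limit of > 100000 nM in this assay, at which 4 of the 4 values shown sit. The compounds shown leave open how far any of these carbonyl substituents moves the read-out in this assay.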